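Replacing 4-hydroxycyclohexyl with cyclobutylmethyl on an amide-type nitrogen

The compounds below may be only part of what the source reports. "The series", "measured", "known", "first", "only" and "open" are said of these compounds alone.

- Compound 1 `CC(C)c1ccccc1NC(=O)N1CCC(c2nc(-c3ccc4ccccc4n3)no2)CC1`: 480 nM
- Compound 2 `O=C(N1CCC(c2nc(-c3ccc4ccccc4n3)no2)CC1)N1CCCc2ccccc21`: 2300 nM
- Compound 3 `O=C(NC1CCC(O)CC1)N1CCC(c2nc(-c3ccc4ccccc4n3)no2)CC1`: 2700 nM

In a functional assay on Shh Light II cells (Mus musculus) for inhibition, read by a luciferase reporter (on this read-out higher numbers stand for weaker inhibition and lower numbers for stronger inhibition), compound 3 gives 2700 nM, the highest number of the three, although it cannot be separated from compound 2: the data show a 1.2-fold higher number from compound 2 to compound 3 (0.07 log units; within the scatter). Compound 1 stands clearly apart, with a 5.6-fold higher number from compound 1 to compound 3 (0.75 log units; beyond the scatter).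

Compound 4 `O=C(NCC1CCC1)N1CCC(c2nc(-c3ccc4ccccc4n3)no2)CC1` has cyclobutylmethyl in place of 4-hydroxycyclohexyl on an amide-type nitrogen. Going by the values given here, no measured compound carries cyclobutylmethyl, so its effect has not been observed directly. Three measured steps alter the same part of the molecule. Besides the two above, there is a 4.8-fold higher number from compound 1 to compound 2 (0.68 log units; beyond the scatter). Both modest steps start from compound 1 and remove its 2-isopropylphenyl group. The change to compound 4 instead keeps a non-aromatic ring of carbon only on the nitrogen, so the closest guide is the small step to compound 3 from compound 2, a 1.2-fold higher number from compound 2 to compound 3 (0.07 log units; within the scatter). No step beyond the scatter is therefore expected in this assay, with at most a slight drift to a lower number. The expected step is a 1.4-fold lower number from compound 3 to compound 4 (0.13 log units; within the scatter). For compound 4 the estimated value is 2000 nM, with an expected range from 800 nM to 5000 nM.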

Compound 4, half-maximal inhibitory concentration: 410 nM
For compound 4 the middle estimate is 4.9-fold (0.69 log units) above the measured one, and the stated range ends above it.
By their numbers in this assay, from the lowest: compounds 4 and 1 (each within the scatter of the next); then compounds 2 and 3 (each within the scatter of the next).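

At this amide-type nitrogen, an aromatic group is not required for the lower numbers in this assay: with cyclobutylmethyl in place of 2-isopropylphenyl, the data show a 1.2-fold lower number from compound 1 to compound 4 (0.07 log units; within the scatter). A non-aromatic ring of carbon only on this nitrogen does not by itself fix the number either, since compound 3 and compound 4 both carry one, yet there is a 6.6-fold lower number from compound 3 to compound 4 (0.82 log units; beyond the scatter), and the exchange of 1,2,3,4-tetrahydroquinolin-1-yl for (cyclobutylmethyl)amino on the carbonyl carbon gives a 5.6-fold lower number from compound 2 to compound 4 (0.75 log units; beyond the scatter). Nothing available on these compounds accounts for the separation between cyclobutylmethyl and 4-hydroxycyclohexyl.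

That change alters the ring size, the hydroxyl group and the link to the nitrogen all at once, so the compounds shown cannot assign the step to any one of them. From the compounds shown here alone, whether a plain cyclohexyl group would stand with compound 3 or with compound 4 remains open, as does the outcome for a cyclobutyl group set directly on the nitrogen or for a longer chain such as n-pentyl.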